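Chloro in place of hydrogen on the core of compound 2

The compounds below may be only part of what the source reports. "The series", "measured", "known", "first", "only" and "open" are said of these compounds alone.

For the measured compounds named here, in a functional assay on HUVEC cells (Homo sapiens) for inhibition, using NADPH, with a stated time of 2 h (on this read-out higher numbers stand for weaker inhibition and lower numbers for stronger inhibition), compound 2 (`O=c1cc(COc2cccc(OCC3CCOCC3)c2)[nH]c2ccccc12`) gives 590 nM, the higher of the two numbers so far, while compound 1 (`Cc1c(COc2cccc(OCC3CCOCC3)c2)[nH]c2ccccc2c1=O`) gives 8.9 nM. Compound 3 (`O=c1c(Cl)c(COc2cccc(OCC3CCOCC3)c2)[nH]c2ccccc12`) has chloro in place of hydrogen on an aromatic carbon, two atoms from the ring nitrogen: chloro in place of hydrogen on an aromatic carbon.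

Going by the values given here, one measured step bears on this change: a 66-fold higher number from compound 1 to compound 2 (1.82 log units; beyond the scatter). This large step, beyond the scatter, has hydrogen in place of methyl on the same aromatic carbon that takes the chloro in compound 3. Among the compounds with values here, the series therefore holds one comparison at this carbon, and no chloro compound has been measured. With methyl there, compound 1 stands at 8.9 nM, so chloro is expected to bring the number down towards that level, though perhaps not all the way.

The expected change in this assay is a large step to a lower number, a 30-fold lower number from compound 2 to compound 3 (1.47 log units; beyond the scatter). Compound 3 is estimated at 20 nM, with an expected range of 6 nM to 100 nM.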

Compound 3, half-maximal inhibitory concentration in the HUVEC assay: 12 nM
Beside the measured number, compound 3's estimate is 1.7-fold (0.22 log units) above it; the range from low to high includes it.
By their numbers in the HUVEC assay, from the lowest: compounds 1 and 3 (each within the scatter of the next); then compound 2.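

In the HUVEC assay a second group at this aromatic carbon, two atoms from the ring nitrogen, now gives a large step from hydrogen (a 49-fold lower number from compound 2 to compound 3 (1.69 log units; beyond the scatter)), so the earlier step with methyl (a 66-fold higher number from compound 1 to compound 2 (1.82 log units; beyond the scatter)) is no longer a single case, and chloro and methyl cannot be told apart on this read-out: compound 3 gives 12 nM and compound 1 gives 8.9 nM (a 1.3-fold higher number from compound 1 to compound 3 (0.13 log units; within the scatter)). In a physicochemical assay for solubility, at pH 6.8 (a higher number here means a more soluble compound, a lower number a less soluble compound), compound 2 gives 4000 nM and compound 3 gives 2000 nM, so the same hydrogen-to-chloro change stays within the scatter (a 2.0-fold lower number from compound 2 to compound 3 (0.30 log units; within the scatter)), and the large step in the HUVEC assay has no counterpart beyond the scatter on that read-out. Nothing in hand explains why either group reads so differently from hydrogen at this carbon.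

How a nitrile, a methoxy group or an aminomethyl group at this carbon would read in the HUVEC assay remains open, so the two groups shown do not yet define what the position accepts. Also open, on these data alone, is whether the step from hydrogen to chloro keeps its size when the side chain of compound 3 is changed, for example with a carboxylic acid or an amine in place of the ether-linked ring.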